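A few compounds are considered here, and "the series" means these few. Any claim that something is new, unique, unknown or untested is made for them only; others in the source may bear on it.

Measured compounds:
compound 1 `Nc1c(C(=O)N[C@H]2CC[C@@H](c3ccccc3)CC2)[nH]c(=O)[nH]c1=O` — 91 nM
compound 2 `Nc1c(C(=O)N[C@H]2CC[C@@H](c3ccc(OCc4ccccc4)cc3)CC2)[nH]c(=O)[nH]c1=O` — 21 nM
compound 3 `Nc1c(C(=O)N[C@@H]2CCCc3c(OCc4ccccc4)cccc32)[nH]c(=O)[nH]c1=O` — 49 nM

In an assay on cells for inhibition of endothelial lipase (Homo sapiens), read by LC-MS, with stated times of 10 min and 30 min (a lower number here means a stronger inhibitor, a higher number a weaker inhibitor), compound 1 gives the highest of the three numbers. Its nearest neighbour is compound 3, which gives 49 nM in this assay, within the scatter of compound 1. The furthest is compound 2, reached by a single change: a 4.3-fold lower number from compound 1 to compound 2 (0.64 log units; beyond the scatter). That step lies beyond the scatter and is modest.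

Compound 4 `O=C(N[C@H]1CC[C@@H](c2ccccc2)CC1)c1[nH]c(=O)[nH]c(=O)c1NC1CCCC1` is not yet measured. It differs from compound 1 in one place: cyclopentyl in place of hydrogen on a nitrogen on an aromatic ring. Within the data shown here, none of the measured steps touches this nitrogen; the only measured step, a 4.3-fold lower number from compound 1 to compound 2 (0.64 log units; beyond the scatter), concerns an aromatic carbon on the far side of the shared core and so does not bear on the change in compound 4. Among the measured compounds shown here, the pair of compound 1 and compound 3 shows only that the two values sit within the scatter of each other.

For the measured compounds named here, with no step at this position to draw on, the step from compound 1 to compound 4 in this assay is expected to be small, and its direction cannot be told from the available numbers: a 1.6-fold higher number from compound 1 to compound 4 (0.22 log units; within the scatter). Compound 4 is therefore estimated at 150 nM, with a range from 40 nM to 600 nM.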

Compound 4, half-maximal inhibitory concentration: 156 nM
Compound 4: the middle estimate sits 1.0-fold (0.02 log units) below what was measured, within the range that was stated.
By their numbers in this assay, from the lowest: compound 2; then compounds 3, 1 and 4 (each within the scatter of the next, the first and the last beyond it).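

In this assay, the nitrogen on an aromatic ring now has a measured step of its own: cyclopentyl in place of hydrogen, the change from amino to cyclopentylamino, gives a 1.7-fold higher number from compound 1 to compound 4 (0.23 log units; within the scatter) and so stays within the scatter. Compounds 1, 2 and 3 all carry the same amino group and could say nothing about this nitrogen, whereas compound 4 shows that, with the rest of compound 1 unchanged, a substituent of 5 heavy atoms in a five-membered carbon ring can stand on it without a step beyond the scatter. Nothing measured here accounts for this result, and the size of the step is all that can be reported.

This single example leaves open how the same nitrogen would respond to a smaller group such as methyl, to a longer chain such as n-hexyl, or to a chain ending in an amine or a carboxylic acid. It also leaves open whether cyclopentylamino would give a similar step on the benzyloxy-bearing compound 2 or on compound 3, whose other parts differ from those of compound 1.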